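Chloro for tert-butyl on the aryl ether of the series

The source may report more compounds than this note shows. Statements on the series, on what has been measured and on what is new or still open speak of the compounds shown alone.

Compound 1 `CC(C)(C)c1ccc(OCCCON2C(N)=NC(N)=NC23CCSCC3)cc1` has no result in an assay on isolated protein for inhibition of Dihydrofolate reductase (Homo sapiens), read by spectrophotometry, using NADPH, with stated times of 5 s and 6 min; on this read-out higher numbers stand for weaker inhibition and lower numbers for stronger inhibition; for compound 1 the read-out is "not determined" (no result reported), so it stands at no number in this assay. Within the data shown here, the only measured member is compound 2 `NC1=NC2(CCOCC2)N(OCCCOc2ccc(Br)cc2)C(N)=N1`, and in this assay compound 2 gives 32.5 nM. Compound 3 `NC1=NC2(CCSCC2)N(OCCCOc2ccc(Cl)cc2)C(N)=N1` is not yet measured. It keeps the shared core of compound 1 and alters only the aryl ether end: chloro in place of tert-butyl on an aromatic carbon. Among the measured compounds shown here, no measured pair bears this exact exchange, so the size of the step from compound 1 to compound 3 in this assay cannot be read from the series; the expectation is a shift no larger than the usual scatter, in no settled direction. Compound 3 is estimated at 30 nM in this assay, with a range of 10 nM to 100 nM, because compound 2 in this assay gives 32.5 nM and compound 3 shares with it a halogen on the same aromatic carbon and the same chain to the core. This estimate rests on one measured compound only and should be treated as provisional until compound 1 or compound 3 is measured.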

Compound 3, half-maximal inhibitory concentration: 18.3 nM
Compound 3: middle estimate off by 1.6-fold (0.21 log units), on the high side, and the stated range covers the measured number.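

In this assay compound 1 gives "not determined" (no result reported) and compound 3 gives 18.3 nM and so no step can be read from compound 1 to compound 3. The compounds shown leave open what the exchange of tert-butyl for chloro on the shared core does to inhibition. No measured evidence bears on this result.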